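Ring Closure at the Amino Substituent of Compound 2

The source may hold more compounds than are shown below. What is called first, only, known or untested is meant among the compounds shown, and "the series" means these compounds.

Measured compounds:
compound 1 `CC(O)(C#Cc1cccc(Nc2ncnc3[nH]ccc23)c1)c1nccs1`, 1640 nM
compound 2 `CN(C)CCN(C)c1ccc(C#CC(C)(O)c2nccs2)cc1Nc1ncnc2[nH]ccc12`, 484 nM
compound 3 `CC(O)(C#Cc1ccc(N2CCCC2)c(Nc2ncnc3[nH]ccc23)c1)c1nccs1`, 107 nM

In an assay for inhibition of mitogen-activated protein kinase kinase kinase 14 (Homo sapiens), read by luminescence and ADP-Glo, with a stated time of 120 min, in the presence of a further agent that is not named here (a higher number here means a weaker inhibitor, a lower number a stronger inhibitor), compound 2 gives 484 nM, the second highest of the three numbers: compound 1 sits a 3.4-fold lower number from compound 1 to compound 2 (0.53 log units; beyond the scatter) away on one side, and compound 3 on the other, with a 4.5-fold lower number from compound 2 to compound 3 (0.66 log units; beyond the scatter).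

Compound 4 `CN1CCCN(c2ccc(C#CC(C)(O)c3nccs3)cc2Nc2ncnc3[nH]ccc23)CC1` is not yet measured. It differs from compound 2 by one change: 4-methyl-1,4-diazepan-1-yl in place of (2-(dimethylamino)ethyl)(methyl)amino on an aromatic carbon.

Among the compounds with values here, two measured steps bear on this. Replacing hydrogen on the shared core of compound 1 with an acyclic amino chain gave a 3.4-fold lower number from compound 1 to compound 2 (0.53 log units; beyond the scatter), whereas a ring at the same place gave a 15-fold lower number from compound 1 to compound 3 (1.19 log units; beyond the scatter); the direct comparison of the two substituents is a 4.5-fold lower number from compound 2 to compound 3 (0.66 log units; beyond the scatter). The group entering in compound 4 is a ring, like that of compound 3, yet it also carries the second nitrogen found in the chain of compound 2, so a step of intermediate size in the direction of a lower number is expected in this assay, though it may stay within the scatter.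

For compound 4 the expected result in this assay is 220 nM, with a range from 70 nM to 650 nM, corresponding to an estimated step of a 2.2-fold lower number from compound 2 to compound 4 (0.34 log units; beyond the scatter).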

Compound 4, half-maximal inhibitory concentration: 60.1 nM
Compound 4: the middle estimate sits 3.7-fold (0.56 log units) above what was measured, and the stated range ends above it.
By their numbers in this assay, from the lowest: compounds 4 and 3 (each within the scatter of the next); then compound 2; then compound 1.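

In this assay, tying the open chain of compound 2 into 4-methyl-1,4-diazepan-1-yl gives an 8.1-fold lower number from compound 2 to compound 4 (0.91 log units; beyond the scatter), so a substituent with the same count of nitrogens as that chain can reach low numbers at this position once it is a ring. The earlier compounds shown here could not show this, as their only ring, pyrrolidin-1-yl, differed from the chain both in being a ring and in lacking the second nitrogen. The two rings are not told apart here, with a 1.8-fold lower number from compound 3 to compound 4 (0.25 log units; within the scatter), and measured from the hydrogen of the core the seven-membered ring gives a 27-fold lower number from compound 1 to compound 4 (1.44 log units; beyond the scatter), a large step like that to compound 3.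

Nothing given here explains why the rings and the open chain differ in this assay. From the compounds shown here alone, it remains open whether a piperazine or a morpholine at this aromatic carbon would match these two rings, and whether the methyl group on the second nitrogen of 4-methyl-1,4-diazepan-1-yl contributes to the result, which a diazepane ring without that methyl group could test.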